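Compound 2 to compound 3: butyl to propyl

A few compounds are considered here, and "the series" means these few. Any claim that something is new, unique, unknown or untested is made for them only; others in the source may bear on it.

compound 1 `O=C1c2c[n+]([O-])c3ccccc3c2C(=O)c2c1c1ccccc1n2CCCCN1CCNCC1` gives 1380 nM
compound 2 `CCCCN1CCN(CCCCn2c3c(c4ccccc42)C(=O)c2c[n+]([O-])c4ccccc4c2C3=O)CC1` gives 5690 nM

Both values come from a toxicity assay on L02 cells (Homo sapiens) for cytotoxicity, read by MTT assay, with a stated time of 72 h (a higher number here means a weaker inhibitor, a lower number a stronger inhibitor), and compound 2 holds the higher of the two numbers. Compound 3 `CCCN1CCN(CCCCn2c3c(c4ccccc42)C(=O)c2c[n+]([O-])c4ccccc4c2C3=O)CC1` differs from compound 2 by hydrogen in place of methyl on a saturated chain carbon, three bonds along the chain from an amine nitrogen in a ring and thus carries propyl where compound 2 carries butyl. Among the measured compounds shown here, the one measured step bearing on this change is a 4.1-fold higher number from compound 1 to compound 2 (0.62 log units; beyond the scatter) with butyl in place of hydrogen on an amine nitrogen in a ring. That step is modest and beyond the scatter. For the measured compounds named here, no propyl compound has been measured, so the expectation rests on this single step. Compound 3 still carries a chain on that nitrogen, so only part of the step should be given back. In this assay the expected change is a 1.5-fold lower number from compound 2 to compound 3 (0.18 log units; within the scatter) and this small move toward a lower number may not clear the scatter. For compound 3 the estimated value is 3800 nM within an expected range of 1800 nM to 7500 nM in this assay.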

Compound 3, half-maximal inhibitory concentration: 6830 nM
Estimate against measurement, compound 3: 1.8-fold (0.25 log units) below; measured number inside the range.
By their numbers in this assay, from the lowest: compound 1; then compounds 2 and 3 (each within the scatter of the next).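

In this assay the change from butyl to propyl gives a 1.2-fold higher number from compound 2 to compound 3 (0.08 log units; within the scatter), so removing this methyl, three bonds along the chain from an amine nitrogen in a ring, leaves the number within the scatter. Propyl in place of hydrogen on that nitrogen gives a 4.9-fold higher number from compound 1 to compound 3 (0.69 log units; beyond the scatter), so among these compounds the readable separation is that of hydrogen from either chain, while butyl and propyl do not separate. Nothing available gives a reason for this reading.

Still open, on these data alone, is whether methyl or ethyl on that nitrogen would sit with compound 1 or with the butyl and propyl compounds, and whether a longer chain such as hexyl would stay with them. Also open, as far as these compounds go, is how a chain ending in a hydroxyl or a carboxylic acid would read at this nitrogen.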